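A few compounds are considered here, and "the series" means these few. Any claim that something is new, unique, unknown or untested is made for them only; others in the source may bear on it.

Compound 1 `C=CC(=O)Nc1ccc(Cn2nc(-c3ccc(Oc4ccccc4)cc3)cc2C(=O)O)cc1` sits at the limit of a functional assay on Z-138 cells (Homo sapiens) for inhibition, read by luminescence and CellTiter-Glo, with a stated time of 72 h (on this read-out lower numbers stand for stronger inhibition and higher numbers for weaker inhibition), where compound 1 gives > 60000 nM, a limit rather than a number. Compound 2 `O=C(CCl)Nc1ccc(Cn2nc(-c3ccc(Oc4ccccc4)cc3)cc2C(=O)O)cc1` gives 1500 nM in this assay, and compound 3 `C/C=C/C(=O)Nc1cccc(Cn2nc(-c3ccc(Oc4ccccc4)cc3)cc2CO)c1` gives 5700 nM. Going by the values given here, the one measured step, an at least 40-fold lower number from compound 1 to compound 2 (1.60 log units; beyond the scatter), concerns the carbonyl carbon bearing vinyl or chloromethyl and, because it starts from the limit (the limit of > 60000 nM in this assay, at which 1 of the 3 values shown sits), fixes only a floor on its size. Compound 4 `C=CC(=O)Nc1ccc(Cn2nc(-c3ccc(Oc4ccccc4)cc3)cc2C(=O)OCC)cc1` differs from compound 1 by ethyl in place of hydrogen on an oxygen next to a carbonyl group. Among the compounds with values here, no measured pair carries that change, so no step bears on it directly, and no direction beyond the scatter is expected; with compound 1 at the limit the estimate stays loose. Compound 4 is expected to give about 30000 nM in this assay, between 5000 nM and 60000 nM, an estimated at least 2.0-fold lower number from compound 1 to compound 4 (0.30 log units; that floor lies within the scatter).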

Compound 4, half-maximal inhibitory concentration: 12500 nM
For compound 4 the middle estimate is 2.4-fold (0.38 log units) above the measured one; low and high end bracket the measured number.
By their numbers in this assay, from the lowest: compound 2; then compound 3; then compound 4. At a limit, above all of these: compound 1.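

Going by these compounds alone, replacing carboxy with ethoxycarbonyl gives the first measured change at this position: in this assay the step is an at least 4.8-fold lower number from compound 1 to compound 4 (0.68 log units; beyond the scatter), with the vinyl carbonyl left in place. The position therefore affects the read-out beyond the scatter, though the step gives only a floor on its size, because compound 1 stands at a limit: the limit of > 60000 nM in this assay, at which 1 of the 4 values shown sits. On these data alone, whether ethoxycarbonyl has the same effect when chloromethyl replaces vinyl remains open. Also open, as far as these compounds go, is what a longer chain than ethyl, or an amide in place of the ester, would give here.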